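Cyclohexyl for 4-fluorophenyl in compound 4: notes

This account rests on a few compounds, and the source may have more. Where it says the series, first, only, none or still open, it means among the compounds named here.

Measured so far in a functional assay on SW620/5-FU cells (Homo sapiens) for cytotoxicity, read by MTT assay, with a stated time of 48 h, in the presence of a further agent that is not named here; a lower number here means that less compound is needed, a higher number that more compound is needed for the effect:
compound 1 `Cc1nn(C)c2nc(NNC(=O)Nc3cc(Cl)nc(Cl)c3)cc(-c3ccc(F)cc3)c12` gives 17400 nM
compound 2 `COc1cc(NC(=O)NNc2cc(-c3ccc(F)cc3)c3cnn(C)c3n2)cc(Cl)n1` gives 24100 nM
compound 3 `COc1ccc(-c2cc(NNC(=O)Nc3cc(Cl)nc(OC(C)C)c3)nc3c2cnn3C)cc1` gives 47100 nM

Compound 1 has the lowest number of the three. Compound 2 sits within the scatter of it, so no order between the two is claimed. Compound 3 lies beyond the scatter on the higher side. No pair among these differs in only one place, so no single-change step is available, and nothing in the series speaks directly to the change now considered.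

Compound 4 `Cc1nn(C)c2nc(NNC(=O)Nc3cc(Cl)nc(Cl)c3)cc(C3CCCCC3)c12` is the unmeasured analogue of compound 1. It differs in one place: cyclohexyl in place of 4-fluorophenyl on an aromatic carbon. For the measured compounds named here, the series gives no precedent for a non-aromatic ring at this position, and the three values shown are all in the same broad region, so the expectation is anchored on compound 1 at 17400 nM with a wide margin. A step of modest size toward a higher number is expected, a 1.5-fold higher number from compound 1 to compound 4 (0.17 log units; within the scatter), though a step of no size beyond the scatter is equally plausible. For compound 4 in this assay the estimate is 26000 nM, within 9000 nM to 80000 nM.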

Compound 4, half-maximal effective concentration: 22000 nM
Compound 4: the middle estimate sits 1.2-fold (0.07 log units) above what was measured, within the range that was stated.
By their numbers in this assay, from the lowest: compounds 1, 4, 2 and 3 (each within the scatter of the next, the first and the last beyond it).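

In this assay, for the compounds shown here, cyclohexyl in place of 4-fluorophenyl on an aromatic carbon gives a 1.3-fold higher number from compound 1 to compound 4 (0.10 log units; within the scatter) and provides the first single-change step. The two compounds therefore cannot be told apart by this read-out, which shows that for this pair, at this position opposite the ring nitrogen, a six-membered aromatic ring of carbon only and a six-membered non-aromatic ring of carbon only are equivalent within the scatter. No measurement on these compounds accounts for this result, and the step describes only the effect of the swap on the core of compound 1.

On these data alone, whether the position accepts groups of another kind remains open: an amine, a carboxylic acid, a longer chain such as n-hexyl, or a smaller ring such as cyclopropyl could each test how far the equivalence extends. As far as these compounds go, it is also open whether cyclohexyl gives a similar result with the other substitution patterns, such as those of compound 2 and compound 3, which differ from compound 1 in more than one place.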